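A few compounds are considered here, and "the series" means these few. Any claim that something is new, unique, unknown or untested is made for them only; others in the source may bear on it.

Compound 2 `CN(C)CCCNc1ccc(/N=N/c2ccc([N+](=O)[O-])cc2)cc1` carries nitro on one of its aromatic rings. In an ADME assay on BHK-21 cells (Mesocricetus auratus) for cytotoxicity, read by MTT assay, with a stated time of 96 h (a higher number here means that more compound is tolerated, a lower number that less compound is tolerated), compound 2 gives only a limit, > 100000 nM, so no number stands for it, just the limit. Compound 3 `FC(F)(F)c1cccc(/N=N/N2CCCC2)c1` likewise returns only a limit in this assay, > 100000 nM. Going by the values given here, compound 1 `O=[N+]([O-])c1cccc(/N=N/N2CCCC2)c1` is the single compound with a number, giving 42000 nM in this assay. Among the compounds with values here, the one step that can be sized, an at least 2.3-fold higher number from compound 1 to compound 3 (0.37 log units; beyond the scatter), runs from a number into the limit, and the limit of > 100000 nM in this assay, at which 2 of the 3 values shown sit, is where most of the series sits.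

Compound 4 `Cc1ccc(/N=N/c2ccc(NCCCN(C)C)cc2)cc1` differs from compound 2 in one place: methyl in place of nitro on an aromatic carbon. The step from compound 1 to compound 3 also removes nitro, though with a different entering group, and it moved toward more tolerance. Since compound 2 already stands at the limit, compound 4 is expected to remain at the limit, with a step that the limit leaves unreadable from compound 2 to compound 4 expected as no step beyond the scatter. The estimate for compound 4 is 150000 nM, ranging from 60000 nM to 400000 nM.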

Compound 4, half-maximal cytotoxic concentration: > 100000 nM
Compound 4: no number, only a limit; the forecaster's own chance of this, stated with the estimate: 75%; the middle value is on the limit's open side.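

Compound 2 and compound 4 both return only a limit in this assay, so methyl in place of nitro gives no readable step: the limit of > 100000 nM in this assay, at which 3 of the 4 values shown sit. The compounds shown leave open where either compound truly lies past that limit, and whether the two differ at all.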